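Thiourea nitrogen substituent: phenyl to allyl in the stomach read-out

The compounds below may be only part of what the source reports. "The series", "measured", "known", "first", "only" and "open" are said of these compounds alone.

Compound 1 `O=c1ccc(-c2ccccc2)nn1CCCCNC(=S)Nc1ccc(Cl)cc1`: in a functional assay on the whole organism (stomach) with Rattus norvegicus as the target (on this read-out lower numbers stand for an effect already at smaller amounts and higher numbers for an effect only at larger amounts of compound), compound 1 gives only the limit > 100 mg/kg.
Compound 2 `CC/N=C(\S)NCCCCCn1nc(-c2ccccc2)ccc1=O`: compound 2 gives 51.8 mg/kg.
Compound 3 `O=c1ccc(-c2ccccc2)nn1CCCCNC(=S)Nc1ccccc1`: compound 3 gives only the limit > 100 mg/kg.

Compound 3 stands at the limit of this assay, not at a number; the limit of > 100 mg/kg in this assay, at which 2 of the 3 values shown sit, describes its position. Among the compounds with values here, the one computable step among measured compounds is a step that the two limits leave unreadable from compound 1 to compound 3, which runs from one limit to another, so its size cannot be read. Compound 4 `C=CCNC(=S)NCCCCn1nc(-c2ccccc2)ccc1=O` differs from compound 3 in one place: allyl in place of phenyl on an amide-type nitrogen. Within the data shown here, no measured step changes the group on this nitrogen, so no step bears directly on the change. Among the measured compounds shown here, compound 2, the one compound in the set that gives a number, differs from compound 3 in more than one place, so no step between them can be read; its value shows only that a number is reachable. Compound 4 is therefore expected to give a number rather than a limit in this assay, an estimated step of an at least 1.6-fold lower number from compound 3 to compound 4 (0.22 log units; that floor lies within the scatter), though the limit at compound 3 leaves the size uncertain. The estimate for compound 4 is 60 mg/kg, with a range from 25 mg/kg to 150 mg/kg.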

Compound 4, dose for half-maximal effect: > 100 mg/kg
Compound 4 ended at the assay's limit (the forecaster's own chance of this, stated with the estimate: 40%); middle value at least 1.6-fold (0.22 log units) away from the limit.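

Putting allyl in place of phenyl on this amide-type nitrogen does not move the compound off the limit in this assay, so removing the aromatic ring from this position is not enough on its own to give a number. The steps to compound 4 from compound 3 and from compound 1 run from limit to limit and cannot be read, and the limit now describes most of the series: the limit of > 100 mg/kg in this assay, at which 3 of the 4 values shown sit.

Within the data shown here, the one readable step is an at least 1.9-fold higher number from compound 2 to compound 4 (0.28 log units; that floor lies within the scatter), so it gives only a floor and no exact size.

As far as these compounds go, how far compound 1, compound 3 and compound 4 each lie past the limit stays open. Also open, from the compounds shown here alone, is whether a benzyl, cyclohexyl or methyl group on this nitrogen would give a number in this assay.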